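Vinyl to (3-bromopropyl)carbamoyl: an untested change

The compounds below may be only part of what the source reports. "The series", "measured", "known", "first", "only" and "open" are said of these compounds alone.

In a functional assay on MCF7 cells (Homo sapiens) for inhibition, read by radiometric assay and XTT assay (on this read-out higher numbers stand for weaker inhibition and lower numbers for stronger inhibition), compound 1 `C=CCOC1=CC(=O)S[C@]1(C)CCCCCC` gives 9 ug/mL and sits at the low end of the three numbers, together with compound 2 `C=CCOC1=CC(=O)S[C@]1(C)CCCCCCCC` at 14.5 ug/mL. Compound 3 `C=CCC1(C)C(=O)S[C@](C)(CCCCCCCC)C1=O` stands apart at 40.5 ug/mL. Compound 4 `CCCCCC[C@@]1(C)SC(=O)C=C1OCC(=O)NCCCBr` carries (3-bromopropyl)carbamoyl in place of vinyl on a saturated chain carbon bound to an oxygen on an unsaturated carbon. Within the data shown here, the one measured step, a 1.6-fold higher number from compound 1 to compound 2 (0.21 log units; within the scatter), concerns a different part of the structure, and no measurement tests this place. No shift beyond the scatter is therefore expected in this assay, though with little support. The expected step is a 1.3-fold higher number from compound 1 to compound 4 (0.12 log units; within the scatter). Compound 4 is estimated at 12 ug/mL, with an expected range of 5 ug/mL to 30 ug/mL.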

Compound 4, half-maximal inhibitory concentration: 21 ug/mL
Compound 4: the middle estimate sits 1.8-fold (0.24 log units) below what was measured; measured number inside the range.
By their numbers in this assay, from the lowest: compounds 1, 2, 4 and 3 (each within the scatter of the next, the first and the last beyond it).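

In this assay, the place on a saturated chain carbon bound to an oxygen on an unsaturated carbon now has a reading of its own: (3-bromopropyl)carbamoyl in place of vinyl gives a 2.3-fold higher number from compound 1 to compound 4 (0.37 log units; beyond the scatter). This modest step lies beyond the scatter, so the change at this place does register, yet inhibition remains readable with the larger group. Nothing available accounts for the step.

As far as these compounds go, whether it follows from the bromine, the amide hydrogen or the longer group stays open. An amine in place of the bromine, or a carboxylic acid at this place, would help separate these parts.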